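Carbamate in place of the amide on the shared core

The compounds below may be only part of what the source reports. "The series", "measured", "known", "first", "only" and "open" are said of these compounds alone.

Compound 1 `Cc1cc(C(=O)NCc2cccnc2)nn1Cc1cc(Cl)ccc1OCc1ccccc1` is reported in a physicochemical assay for lipophilicity, at pH 7.4 (on this read-out higher numbers stand for higher lipophilicity and lower numbers for lower lipophilicity), only as a limit, > 3.7. Its standing among the measured values cannot be placed more finely, since the limit of > 3.7 in this assay, at which 2 of the 3 values shown sit, marks where most of the series sits. Compound 2 `Cc1cc(C(N)=O)nn1Cc1cc(Cl)ccc1OCC(C)C` gives 3.1 in this assay. Compound 3 `Cc1cc(NC(=O)C2CCCC2)nn1Cc1cc(Cl)ccc1OCC(C)C` is reported in this assay as a limit, > 3.7. Within the data shown here, the step of a number at least 0.60 log units higher from compound 2 to compound 3 (beyond the scatter) is the one measured change at the same position, but it exchanges a different group than the one changed in compound 4 `Cc1cc(NC(=O)O[C@H]2CCOC2)nn1Cc1cc(Cl)ccc1OCc1ccccc1`; the change here is (((oxolan-3-yl)oxy)carbonyl)amino in place of ((pyridin-3-yl)methyl)carbamoyl on an aromatic carbon. Among the measured compounds shown here, no measured step covers this exchange directly, so no direction beyond the scatter is confidently expected. Compound 4 is estimated at 3.6 (3 to 4.2). The step of a number at least 0.10 log units lower from compound 1 to compound 4 (that floor lies within the scatter) thus expected keeps compound 4 close to the limit.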

Compound 4, distribution coefficient: 2.7
The estimate for compound 4 lay 0.90 log units above the measured number; the whole stated range lies above it.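

Among these compounds, at this position the read-out can fall as well as rise: this assay gives a number at least 1.00 log units lower from compound 1 to compound 4 (beyond the scatter) for (((oxolan-3-yl)oxy)carbonyl)amino in place of ((pyridin-3-yl)methyl)carbamoyl, whereas the one earlier step there was a number at least 0.60 log units higher from compound 2 to compound 3 (beyond the scatter). The drop is a floor and not a full size, since compound 1 stands at a limit: the limit of > 3.7 in this assay, at which 2 of the 4 values shown sit.

The exchange replaces the whole side group, so this pair does not separate the loss of the pyridine ring from the gain of the oxolane ring or the change of link. From the compounds shown here alone, how a plain amine or a carboxylic acid on this aromatic carbon would read in this assay remains open.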